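The compounds below may be only part of what the source reports. "The series", "measured", "known", "first", "only" and "open" are said of these compounds alone.

Compound 3 `COc1cccc(-n2cc(CN3C(=O)C[C@@H]4CC[C@@]3(C)C4(C)C)nn2)c1` sits second highest of the three numbers in a functional assay on A549 cells (Homo sapiens) for inhibition, read by MTT assay, with a stated time of 24 h (on this read-out lower numbers stand for stronger inhibition and higher numbers for weaker inhibition), where it gives 240 nM. Its nearest neighbour is compound 1 `COc1ccccc1-n1cc(CN2C(=O)C[C@@H]3CC[C@@]2(C)C3(C)C)nn1`, which gives 350 nM, and the two lie apart by a 1.5-fold lower number from compound 1 to compound 3 (0.16 log units; within the scatter). Furthest from it is compound 2 `CC1(C)[C@H]2CC[C@]1(C)N(Cc1cn(-c3ccccc3Cl)nn1)C(=O)C2`, which gives 70 nM, separated by a 3.4-fold higher number from compound 2 to compound 3 (0.54 log units; beyond the scatter).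

Compound 4 `CC1(C)[C@H]2CC[C@]1(C)N(Cc1cn(-c3cccc(C#N)c3)nn1)C(=O)C2` differs from compound 3 in one place: cyano in place of methoxy on an aromatic carbon. For the measured compounds named here, no measured pair shows cyano entering anywhere. Going by the values given here, the only step that exchanges the methoxy for another group is a 5.0-fold lower number from compound 1 to compound 2 (0.70 log units; beyond the scatter), chloro in place of methoxy on an aromatic carbon, and that carried the number down by a modest amount. The shift of methoxy between positions, a 1.5-fold lower number from compound 1 to compound 3 (0.16 log units; within the scatter), stayed within the scatter, so the position of a small group on this phenyl has shown little weight so far. On that basis compound 4 is expected to land somewhat lower than compound 3, with the step of a 1.6-fold lower number from compound 3 to compound 4 (0.20 log units; within the scatter) estimated as small and uncertain. Compound 4 is therefore estimated at 150 nM, with a range from 60 nM to 400 nM.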

Compound 4, half-maximal inhibitory concentration: 440 nM
Beside the measured number, compound 4's estimate is 2.9-fold (0.47 log units) below it, outside the stated range (above it).
By their numbers in this assay, from the lowest: compound 2; then compounds 3, 1 and 4 (each within the scatter of the next).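

In this assay, cyano in place of methoxy on an aromatic carbon, meta to a large group, gives a 1.8-fold higher number from compound 3 to compound 4 (0.26 log units; within the scatter), so the two groups cannot be told apart at this place. For the compounds shown here, the step of a 1.3-fold higher number from compound 1 to compound 4 (0.10 log units; within the scatter) also stays within the scatter, which puts the 3-cyanophenyl, 3-methoxyphenyl and 2-methoxyphenyl compounds together, while a 6.3-fold higher number from compound 2 to compound 4 (0.80 log units; beyond the scatter) adds to the earlier steps that leave compound 2, with its 2-chlorophenyl, alone beyond the scatter of all the others. Nothing available here accounts for this result.

Going by these compounds, whether the low number of compound 2 belongs to the chloro group itself or to its place on the phenyl remains open. So does the outcome of an amine or a carboxylic acid on this phenyl.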